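The source may report more compounds than this note shows. Statements on the series, on what has been measured and on what is new or still open speak of the compounds shown alone.

Values in a functional assay on K562 cells (Homo sapiens) for antiproliferative activity, read by MTT assay, with a stated time of 48 h (a lower number here means a stronger inhibitor, a higher number a weaker inhibitor), for the three measured compounds:

Compound 1 `O=C(CCCCCCn1cc(Nc2ncc(Cl)c(Nc3cccc(Cl)c3)n2)cn1)NO` gives 380 nM.
Compound 2 `O=C(CCCCCn1cc(Nc2ncc(Cl)c(Nc3cccc(Cl)c3)n2)cn1)NO` gives 580 nM.
Compound 3 `O=C(CCCCCn1cc(Nc2ncc(Cl)c(Nc3ccccc3Cl)n2)cn1)NO` gives 1810 nM.

Compound 1 and compound 2 share the same core and differ only in the chain that carries the hydroxamic acid: the change from compound 2 to compound 1 is (hydroxycarbamoyl)methyl in place of hydroxycarbamoyl on a saturated chain carbon, five bonds along the chain from an aromatic nitrogen, and it produced a 1.5-fold lower number from compound 2 to compound 1 (0.18 log units; within the scatter). Compound 3 differs from compound 2 in the core itself, by 2-chlorophenyl in place of 3-chlorophenyl on a nitrogen on an aromatic ring, and that change produced a 3.1-fold higher number from compound 2 to compound 3 (0.49 log units; beyond the scatter). Compound 3 therefore stands with the highest number of the three measured compounds, beyond the scatter from both compound 2 and compound 1.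

Compound 4 `O=C(CCCCCCn1cc(Nc2ncc(Cl)c(Nc3ccccc3Cl)n2)cn1)NO` has not yet been measured in this assay. It differs from compound 3 by (hydroxycarbamoyl)methyl in place of hydroxycarbamoyl on a saturated chain carbon, five bonds along the chain from an aromatic nitrogen. This is the same change as the one from compound 2 to compound 1; the place lines read alike word for word, and the change occurs twice among the compounds shown, once measured and once pending. The two pairs sit on cores that differ by 2-chlorophenyl in place of 3-chlorophenyl on a nitrogen on an aromatic ring.

For the measured compounds named here, on the single measured instance of this chain change, the step from compound 3 to compound 4 is expected to be a 1.5-fold lower number from compound 3 to compound 4 (0.18 log units; within the scatter), resting on a 1.5-fold lower number from compound 2 to compound 1 (0.18 log units; within the scatter), which stayed within the scatter. For compound 4 the expected value in this assay is 1200 nM. The estimated range for compound 4 runs from 550 nM to 2600 nM.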

Compound 4, half-maximal inhibitory concentration: 860 nM
Estimate against measurement, compound 4: 1.4-fold (0.14 log units) above, and the stated range covers the measured number.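

In this assay, the chain change gives a 2.1-fold lower number from compound 3 to compound 4 (0.32 log units; beyond the scatter), and its size agrees with the earlier step on the core of compound 2: the same change on two cores in this assay, a 1.5-fold lower number (0.18 log units; within the scatter) from compound 2 to compound 1 and a 2.1-fold lower number (0.32 log units; beyond the scatter) from compound 3 to compound 4, 1.4-fold (0.14 log units) apart, within the scatter of two such steps

Moving the chlorine-bearing phenyl group from 3-chlorophenyl to 2-chlorophenyl also carries across the two chain lengths, with a 2.3-fold higher number from compound 1 to compound 4 (0.35 log units; beyond the scatter): the same change on two cores in this assay, a 3.1-fold higher number (0.49 log units; beyond the scatter) from compound 2 to compound 3 and a 2.3-fold higher number (0.35 log units; beyond the scatter) from compound 1 to compound 4, 1.4-fold (0.14 log units) apart, within the scatter of two such steps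

Across these four compounds, each change therefore has a similar effect whichever form of the other part is present, but this rests on only two pairs per change, so it does not show that either step would hold on any other core, and it gives no reason for either step.

The compounds shown leave open whether a longer chain would continue the direction of the chain step or reverse it, and whether a carboxylic acid in place of the hydroxycarbamoyl end would retain any antiproliferative activity. They also leave open how an unsubstituted phenyl group on the same nitrogen would compare with 3-chlorophenyl and 2-chlorophenyl, and whether the two changes would still combine in the same way with it.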